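Swapping Methyl for Trifluoromethyl on an Aromatic Oxygen

This account rests on a few compounds, and the source may have more. Where it says the series, first, only, none or still open, it means among the compounds named here.

Measured in an ADME assay on RD cells (Homo sapiens) for cytotoxicity; a lower number here means that less compound is tolerated, a higher number that more compound is tolerated:
compound 1 `COc1ccc2c(c1)/C(=N/NC(=S)Nc1ccccc1)C(=O)N2` — > 25000 nM
compound 2 `CCCN(CCC)C(=S)N/N=C1/C(=O)Nc2ccccc21` — > 25000 nM
compound 3 `O=C1Nc2ccccc2/C1=N/NC(=S)Nc1cccc(Cl)c1` — > 25000 nM

The value of compound 1 in this assay is a limit of the assay rather than a number. The same is true of compound 2. It is true of compound 3 as well. All three therefore sit at the limit of > 25000 nM in this assay, at which 3 of the 3 values shown sit, so compound 1 stands nowhere above or below its companions: the three are simply indistinguishable at the edge of what the assay can report.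

Compound 4 `O=C1Nc2ccc(OC(F)(F)F)cc2/C1=N/NC(=S)Nc1ccccc1` is the next compound to be tested in this assay. It differs from compound 1 in one place: trifluoromethyl in place of methyl on an oxygen on an aromatic ring. Going by the values given here, no measured pair in this set shows what such a change does to tolerated concentration, so the expectation for the step rests only on the three limits already seen. The expected step, a step that the limit leaves unreadable from compound 1 to compound 4, is none beyond the scatter. Compound 4 is accordingly expected to give 40000 nM, with a range from 15000 nM to 150000 nM, and most likely to return only a limit again.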

Compound 4, half-maximal cytotoxic concentration: > 25000 nM
Compound 4 was reported as a limit; the forecaster's own chance of this, stated with the estimate: 80%; the middle value does not contradict the limit.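

In this assay, going by these compounds alone, compound 1 and compound 4 both return only a limit, not a number, so no step between them can be read: the limit of > 25000 nM in this assay, at which 4 of the 4 values shown sit.

The compounds shown leave open whether trifluoromethyl in place of methyl changes the tolerated concentration at all.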